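The source may hold more compounds than are shown below. What is called first, only, known or untested is meant among the compounds shown, and "the series" means these compounds.

Compound 1 `CC(C)=CCC1Cc2c(OCc3ccccc3)cc(=O)n(CCCO)c2CC1(C)C` gives -0.3%
Compound 2 `CC(C)=CCC1Cc2c(OCCCNC(=O)c3cccs3)cc(=O)n(CCCO)c2CC1(C)C` gives 33.6%
Compound 3 `CC(C)=CCC/C(C)=C/CC1Cc2c(OCc3ccccc3)cc(=O)n(CCCO)c2CC1(C)C` gives 46.5%

Of the three compounds measured in a functional assay on PANC-1 cells (Homo sapiens) for inhibition, read by MTT assay, with a stated time of 24 h, tested at 10 uM (a lower number here means less inhibition, a higher number more inhibition at the concentration tested (going by the name of the read-out)), compound 3 stands highest. The gap from compound 1 is a number 46.8 percentage points higher from compound 1 to compound 3 (beyond the scatter), and compound 2 lies beyond the scatter below compound 3 as well. Compound 4 `CC(C)=CCC/C(C)=C/CC1Cc2c(OC(=O)Nc3ccccc3F)cc(=O)n(CCCO)c2CC1(C)C` has not yet been measured. It differs from compound 3 in one place: (2-fluorophenyl)carbamoyl in place of benzyl on an oxygen on an aromatic ring. Compound 4 keeps the 3-methylbut-2-en-1-yl chain that sets compound 3 apart from compound 1.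

For the measured compounds named here, only one measured step touches the same oxygen on the aromatic ring: a number 33.9 percentage points higher from compound 1 to compound 2 (beyond the scatter), where a larger group carrying an amide took the place of phenyl. That step went up, and the entering group in compound 4 also brings a hydrogen-bond donor and acceptor, although it is not the same group, so the parallel is loose. Going by the values given here, no measured pair shows a carbamoyl on this oxygen. Compound 4 is therefore expected to stay near or somewhat above compound 3, with a step of a number 5.5 percentage points higher from compound 3 to compound 4 (within the scatter) estimated, and a wide range. The estimate for compound 4 in this assay is 52%, between 25% and 78%.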

Compound 4, a percentage reported as inhibition, at one concentration (the size of the read-out at that concentration, not a potency): 71.6%
Estimate against measurement, compound 4: 19.6 percentage points below; the range from low to high includes it.
By their numbers in this assay, from the lowest: compound 1; then compound 2; then compound 3; then compound 4.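

In this assay, putting (2-fluorophenyl)carbamoyl in place of benzyl on the oxygen on the aromatic ring gives a number 25.1 percentage points higher from compound 3 to compound 4 (beyond the scatter), so this oxygen still moves the read-out when the longer chain of compound 3 is already present. For the compounds shown here, the only earlier change at this oxygen, a number 33.9 percentage points higher from compound 1 to compound 2 (beyond the scatter), came with the shorter chain, so the gain from changing this oxygen's group is now seen with both chains, though with different entering groups. Nothing available explains why the carbamoyl compound reads higher.

The compounds shown leave open whether the carbamoyl link or the fluorine carries the step, which a plain phenylcarbamoyl on this oxygen would help to separate. From the compounds shown here alone, it also remains open how a chain ending in an amine or a carboxylic acid would read here.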